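Swapping a small aromatic ring for a cyclic urea

A few compounds are considered here, and "the series" means these few. Any claim that something is new, unique, unknown or untested is made for them only; others in the source may bear on it.

Compound 2 `CC(C)C(c1ncco1)c1ccc(-c2ccc3cccc(F)c3c2)[nH]c1=O` gives 24 nM in an assay on CHO cells for displacement of a labelled ligand from prostaglandin E2 receptor EP3 subtype (Homo sapiens), read by radioligand binding; on this read-out higher numbers stand for weaker inhibition and lower numbers for stronger inhibition. Among the three measured compounds its number is the highest, yet both neighbours lie within the scatter: compound 3 `CC(C)C(c1ccc(-c2ccc3cccc(F)c3c2)[nH]c1=O)N1CCN/C1=N\C#N` gives 23 nM, and compound 1 `CCn1ncc2c(F)cc(-c3ccc(C(CC)(CC)c4nnc[nH]4)c(=O)[nH]3)cc21` gives 17 nM. Compound 4 `CC(C)C(c1ccc(-c2ccc3cccc(F)c3c2)[nH]c1=O)N1CCNC1=O` differs from compound 2 by 2-oxoimidazolidin-1-yl in place of 1,3-oxazol-2-yl on a saturated chain carbon bound to an aromatic carbon and a saturated chain carbon. Among the compounds with values here, the one measured step that bears on this change, a 1.0-fold lower number from compound 2 to compound 3 (0.02 log units; within the scatter), replaced the same five-membered aromatic ring at the same place with a larger non-aromatic ring and left the number unchanged. A second non-aromatic ring at that place is therefore expected to behave alike, so the step of a 1.0-fold higher number from compound 2 to compound 4 (0.02 log units; within the scatter) is expected to stay within the scatter. Compound 4 is estimated at 25 nM, with a range from 10 nM to 60 nM.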

Compound 4, inhibition constant: 9.1 nM
Compound 4: middle estimate off by 2.7-fold (0.44 log units), on the high side; measured number below the stated range.
By their numbers in this assay, from the lowest: compounds 4, 1, 3 and 2 (each within the scatter of the next, the first and the last beyond it).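

The earlier step suggested that the group at this saturated chain carbon made little difference, but replacing 1,3-oxazol-2-yl with 2-oxoimidazolidin-1-yl gives a 2.6-fold lower number from compound 2 to compound 4 (0.42 log units; beyond the scatter). Two five-membered non-aromatic rings also differ, with a 2.5-fold lower number from compound 3 to compound 4 (0.40 log units; beyond the scatter), so losing aromaticity does not by itself set the number in this assay. No measured evidence explains these steps.

Going by these compounds, it remains open how an open-chain urea or a simple amine would read at this carbon. Also open, on these data alone, is whether 2-oxoimidazolidin-1-yl would give a similar step on the core of compound 1.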